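The source may report more compounds than this note shows. Statements on the series, on what has been measured and on what is new or still open speak of the compounds shown alone.

Working notes on the series. Three compounds have numbers in a functional assay on the whole organism for inhibition, with Rattus norvegicus as the target, read by paw edema, with stated times of 1 h and 0.5 h, at a dose of 100 mg/kg by the oral route; a higher number here means more inhibition at the dose given (going by the name of the read-out), a lower number less inhibition. Compound 1 `Cc1ccccc1S(=O)(=O)N1CC(O)C[C@H]1C(=O)Nc1ccc(C(=O)O)cc1` gives 38.6%. Compound 2 `O=C(O)c1ccc(NC(=O)[C@@H]2CC(O)CN2S(=O)(=O)c2ccccc2)cc1` gives 33.9%. Compound 3 `O=C(O)c1ccc(NC(=O)[C@@H]2CCCN2S(=O)(=O)c2ccccc2)cc1` gives 23.6%, the lowest of the three, with its steps to the other two beyond the scatter. The change between the cores of compound 2 and compound 3 is hydrogen in place of hydroxy on a saturated ring carbon, and this step read a number 10.3 percentage points lower from compound 2 to compound 3 (beyond the scatter).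

Compound 4 `Cc1ccc(S(=O)(=O)N2CCC[C@H]2C(=O)Nc2ccc(C(=O)O)cc2)cc1` is not yet measured. Its difference from compound 3 is methyl in place of hydrogen on an aromatic carbon. The same kind of change has been made once before, from compound 2 to compound 1, as methyl in place of hydrogen on an aromatic carbon; the two differ around the place, one ortho to a large group and the other para to a large group, so the earlier one is a guide of the same kind rather than the same change. That earlier step read a number 4.7 percentage points higher from compound 2 to compound 1 (within the scatter), within the scatter.

Resting on that single step, the expected step from compound 3 to compound 4 is a number 4.4 percentage points higher from compound 3 to compound 4 (within the scatter), a small rise that may not exceed the scatter. Compound 4 is therefore estimated at 28%, between 18% and 38%.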

Compound 4, a percentage reported as inhibition, in the whole organism at one dose (the size of the read-out at that dose, not a potency): 28.8%
Estimate against measurement, compound 4: 0.8 percentage points below, within the range that was stated.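

In this assay the methyl step on the core without the hydroxy, a number 5.2 percentage points higher from compound 3 to compound 4 (within the scatter), agrees with the earlier methyl step on the core that carries it: the same change on two cores in this assay, a number 4.7 percentage points higher (within the scatter) from compound 2 to compound 1 and a number 5.2 percentage points higher (within the scatter) from compound 3 to compound 4, 0.5 percentage points apart, within the scatter of two such steps

Within these four compounds, then, methyl in place of hydrogen on an aromatic carbon reads alike on both cores, and nothing here suggests that the core alters it. This does not show that methyl raises inhibition, as each step taken alone lies within the scatter, and core and position remain tied together: the methyl of compound 4 stands para to a large group, while that of compound 1 sits elsewhere on the ring.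

Open, on these data alone, is how the 4-methylphenyl group reads on the core that carries the hydroxy, a comparison that would separate position from core. Also open, as far as these compounds go, is how groups other than methyl read at this place, such as chloro, methoxy or an amine, and how the series reads with an ester in place of the carboxylic acid.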